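This account rests on a few compounds, and the source may have more. Where it says the series, first, only, none or still open, it means among the compounds named here.

Compound 2 `Cc1ccc(NC(=O)Nc2ccc(Oc3cc(/N=C/N(C)C)ncn3)cc2)cc1C(F)(F)F` is the reference point for this step. In a functional assay on BaF3 cells (Mus musculus) for inhibition, read by CCK-8 assay, with a stated time of 72 h (a higher number here means a weaker inhibitor of growth, a lower number a stronger inhibitor of growth), compound 2 gives 6610 nM, the lower of the two numbers recorded, though compound 3 `Cc1ccc(NC(=O)Nc2ccc(Oc3cc(N(C)CCN(C)C)ncn3)cc2)cc1C(F)(F)F` at 9410 nM sits within the scatter of it. Compound 1 `Cc1ccc(NC(=O)Nc2ccc(Oc3cc(N)ncn3)cc2)cc1C(F)(F)F` reaches only a limit of the assay, > 10000 nM. The steps recorded so far, an at least 1.5-fold lower number from compound 1 to compound 2 (0.17 log units; that floor lies within the scatter), an at least 1.0-fold lower number from compound 1 to compound 3 (0.02 log units; that floor lies within the scatter) and a 1.4-fold higher number from compound 2 to compound 3 (0.15 log units; within the scatter), all stay within the scatter, the first two resting on (the limit of > 10000 nM in this assay, at which 1 of the 3 values shown sits). Compound 4 `Cc1ccc(NC(=O)Nc2ccc(Oc3cc(NCCO)ncn3)cc2)cc1C(F)(F)F` carries a group of 4 heavy atoms (2 carbon, 1 nitrogen, 1 oxygen; no ring) in place of a group of 5 heavy atoms (3 carbon, 2 nitrogen; no ring), on an aromatic carbon. Every change on this aromatic carbon recorded so far has moved the number little, so for compound 4 the expectation is a 1.2-fold higher number from compound 2 to compound 4 (0.08 log units; within the scatter), a step within the scatter. The estimate for compound 4 is therefore 8000 nM, with a range from 3000 nM to 20000 nM.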

Compound 4, concentration for 50% growth inhibition: > 10000 nM
Compound 4: no number, only a limit; the forecaster's own chance of this, stated with the estimate: 35%; at least 1.2-fold (0.09 log units) between middle value and limit.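

In this assay compound 4 gives only a limit, not a number: > 10000 nM. With (2-hydroxyethyl)amino on this aromatic carbon, the steps of an at least 1.5-fold higher number from compound 2 to compound 4 (0.17 log units; that floor lies within the scatter) and an at least 1.0-fold higher number from compound 3 to compound 4 (0.02 log units; that floor lies within the scatter) still show no change beyond the scatter, and the step between the two limits cannot be read. The series now rests partly on a ceiling: the limit of > 10000 nM in this assay, at which 2 of the 4 values shown sit.

As far as these compounds go, whether any group on this carbon can move growth inhibition beyond the scatter remains open. So does how a morpholine, a piperazine or a carboxylic acid at this position would read.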